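A Ring Swap in a Series at the Assay Limit

A few compounds are considered here, and "the series" means these few. Any claim that something is new, unique, unknown or untested is made for them only; others in the source may bear on it.

Compound 1 `COC(=O)N[C@H](C(=O)NN(CCC[C@@](O)(Cc1ccccc1)C(=O)N[C@H]1c2ccccc2C[C@H]1O)Cc1ccc(C#N)cc1)C(C)(C)C`: > 10000 nM
Compound 2 `COC(=O)N[C@H](C(=O)NN(CCC[C@@](O)(Cc1ccccc1)C(=O)N[C@H]1c2ccccc2C[C@H]1O)CC(C)C)C(C)(C)C`: > 10000 nM
Compound 3 `COC(=O)N[C@H](C(=O)NN(CCC[C@@](O)(Cc1ccccc1)C(=O)N[C@H]1c2ccccc2C[C@H]1O)Cc1ccc(-c2cncnc2)cc1)C(C)(C)C`: > 10000 nM

These three compounds were tested in an ADME assay on MT4 cells (Homo sapiens) for cytotoxicity; on this read-out higher numbers stand for lower toxicity in this test and lower numbers for higher toxicity in this test. In this assay compound 3 gives > 10000 nM, which is a limit of the assay and not a number. It has no position above or below the other two, and the series as a whole shows the same picture: the limit of > 10000 nM in this assay, at which 3 of the 3 values shown sit.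

Compound 4 `COC(=O)N[C@H](C(=O)NN(CCC[C@@](O)(Cc1ccccc1)C(=O)N[C@H]1c2ccccc2C[C@H]1O)Cc1ccc(-n2ccnc2)cc1)C(C)(C)C` has not yet been measured. It carries 1H-imidazol-1-yl in place of pyrimidin-5-yl on an aromatic carbon.

The nearest measured change is a step that the two limits leave unreadable from compound 1 to compound 3, which altered the same aromatic carbon. Two further changes, a step that the two limits leave unreadable from compound 2 to compound 3 and a step that the two limits leave unreadable from compound 1 to compound 2, altered the larger group on the saturated chain carbon. None of them has a readable size, so they offer no number to carry over. They show only that all three structures reached the same limit.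

The expected change is a step that the limit leaves unreadable from compound 3 to compound 4, with no direction and nothing expected beyond the scatter. Another limit is the most likely report. Compound 4 is estimated at 12000 nM, with an expected range of 5000 nM to 30000 nM.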

Compound 4, half-maximal cytotoxic concentration: > 10000 nM
Compound 4 gave a limit, no number; the forecaster's own chance of this, stated with the estimate: 85%; the middle value lies beyond the limit too.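

In this assay compound 4 gives > 10000 nM and this is a limit of the assay, not a number. For the compounds shown here, no step from compound 1, compound 2 or compound 3 to compound 4 can be read. The series reads the same throughout: the limit of > 10000 nM in this assay, at which 4 of the 4 values shown sit. The compounds shown leave open how far each lies beyond that limit and whether these changes differ at all.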